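Working notes on a small set at alpha-1 binding

The source may hold more compounds than are shown below. What is called first, only, known or untested is meant among the compounds shown, and "the series" means these compounds.

Measured so far:
compound 1 `O=C1C2CCCN2C(=O)N1CN1CCN(c2cccc(Cl)c2)CC1`: 292 nM
compound 2 `O=C1C2CCCN2C(=O)N1CN1CCN(c2ccc(F)cc2)CC1`: > 1000 nM
compound 3 `O=C1C2CCCN2C(=O)N1CCN1CCN(c2cccc(Cl)c2)CC1`: 500 nM

In an assay on isolated protein for binding affinity to Adrenergic receptor alpha-1 (Rattus norvegicus), read by radioligand binding (on this read-out higher numbers stand for weaker inhibition and lower numbers for stronger inhibition), compound 1 gives 292 nM. For compound 2 the result is a limit of the assay, > 1000 nM, not a number. Compound 3 gives 500 nM in this assay; the difference between its core and the core of compound 1 is not broken down here, and the two values lie within the usual scatter of each other.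

Among the measured compounds shown here, the one counted change is 4-fluorophenyl in place of 3-chlorophenyl on an amine nitrogen in a ring, which gave an at least 3.4-fold higher number from compound 1 to compound 2 (0.53 log units; beyond the scatter).

Compound 4 `O=C1C2CCCN2C(=O)N1CCN1CCN(c2ccc(F)cc2)CC1` is not yet measured. It differs from compound 3 by 4-fluorophenyl in place of 3-chlorophenyl on an amine nitrogen in a ring, the same change as from compound 1 to compound 2, at the same place. Starting from compound 3 with 500 nM, a step of a 3.6-fold higher number from compound 3 to compound 4 (0.56 log units; beyond the scatter) is expected in this assay, at least as large as the earlier one. Because the limit of > 1000 nM in this assay, at which 1 of the 3 values shown sits, already caught compound 2, a limit rather than a number is the likelier outcome for compound 4 as well. Compound 4 is estimated at 1800 nM, expected between 800 nM and 5000 nM.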

Compound 4, inhibition constant: > 1000 nM
Compound 4: a limit, no number; the forecaster's own chance of this, stated with the estimate: 65%; the middle value does not contradict the limit.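

In this assay compound 4 gives > 1000 nM, a limit of the assay and not a number. With 4-fluorophenyl in place of 3-chlorophenyl, the new step is an at least 2.0-fold higher number from compound 3 to compound 4 (0.30 log units; that floor lies within the scatter); it points the same way as the step on the core of compound 1, but its floor alone does not establish a change beyond the scatter on this core. The direction is therefore compatible across the two cores, while the size of the change is not shown to carry over: the same change on two cores in this assay, an at least 3.4-fold higher number (0.53 log units; beyond the scatter) from compound 1 to compound 2 and an at least 2.0-fold higher number (0.30 log units; that floor lies within the scatter) from compound 3 to compound 4; the limit leaves it open whether they differ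

Open, on these data alone, is how a 4-chlorophenyl, a 3-fluorophenyl or an unsubstituted phenyl would read on either core, which would help separate the identity of the halogen from its place on the aromatic ring. Also open, as far as these compounds go, is whether a longer chain, in place of the linking chain of compound 3, would preserve a measurable reading with 3-chlorophenyl.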